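Shortening the amide chain of a fused bicyclic amine

A few compounds are considered here, and "the series" means these few. Any claim that something is new, unique, unknown or untested is made for them only; others in the source may bear on it.

Compound 1 `C[C@H]1C[C@H]1C(=O)N1CC2CNCC2C1`: 19000 nM
Compound 2 `C[C@@H]1C[C@@H]1C(=O)N1CC2CNCC2C1`: 1200 nM

In an assay on SHEP1 cells for agonist activity at Neuronal acetylcholine receptor; alpha4/beta2 (Homo sapiens), read by FLIPR and calcium flux (a lower number here means that less compound is needed, a higher number that more compound is needed for the effect), compound 2 gives 1200 nM, the lowest of the two numbers shown. Among the measured compounds shown here, the only measured step, a 16-fold lower number from compound 1 to compound 2 (1.20 log units; beyond the scatter), concerns two stereocentres and not the size of the acyl group, so it does not bear on the change to compound 3 `CCC(=O)N1CC2CNCC2C1`: a group of 2 heavy atoms (2 carbon; no ring) in place of a group of 4 heavy atoms (4 carbon; one three-membered non-aromatic ring of carbon only), on a carbonyl carbon. For the measured compounds named here, with no measured step of this kind, compound 3 is expected to sit somewhat above compound 2, a 4.2-fold higher number from compound 2 to compound 3 (0.62 log units; beyond the scatter), and its value in this assay is estimated at 5000 nM, within 1500 nM to 20000 nM.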

Compound 3, half-maximal effective concentration: 1300 nM
The estimate for compound 3 lay 3.8-fold (0.59 log units) above the measured number, and the stated range ends above it.
By their numbers in this assay, from the lowest: compounds 2 and 3 (each within the scatter of the next); then compound 1.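

In this assay, the 2-methylcyclopropyl group gives way to ethyl on the carbonyl carbon with a 1.1-fold higher number from compound 2 to compound 3 (0.03 log units; within the scatter), so at this position neither the three-membered ring nor its two defined stereocentres are needed to reach this level. The same exchange starting from the other drawn configuration gives a 15-fold lower number from compound 1 to compound 3 (1.16 log units; beyond the scatter), which leaves that configuration as the outlier of the three. Nothing at hand accounts for either step.

From the compounds shown here alone, it remains open how far the acyl group can shrink or grow at this carbonyl carbon, for instance to methyl or to a longer chain such as butyl. Whether an amine on that chain would change the number is open as well.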